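The source may hold more compounds than are shown below. What is called first, only, known or untested is meant among the compounds shown, and "the series" means these compounds.

Among the measured compounds shown here, compound 1 `CN(C(=O)NC(=O)c1cccc(C(F)(F)F)c1)c1nc(C(F)(F)F)c(C(=O)N/N=C/c2cccc(C(F)(F)F)c2)s1` is one of two compounds measured here. In a functional assay on A549 cells (Homo sapiens) for inhibition, read by MTT assay, with a stated time of 72 h (on this read-out higher numbers stand for weaker inhibition and lower numbers for stronger inhibition), compound 1 gives 8.16 ug/mL, the lower of the two numbers. For the measured compounds named here, its only neighbour, compound 2 `CN(C(=O)NC(=O)c1cccc(C(F)(F)F)c1)c1nc(C(F)(F)F)c(C(=O)N/N=C/c2ccccc2C(F)(F)F)s1`, gives 12.1 ug/mL in this assay, and the step of a 1.5-fold higher number from compound 1 to compound 2 (0.17 log units; within the scatter) shows that exchanging one trifluoromethylphenyl for another on the carbon with a double bond to nitrogen changed little.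

Compound 3 `CN(C(=O)NC(=O)c1ccc(C(F)(F)F)cc1)c1nc(C(F)(F)F)c(C(=O)N/N=C/c2cccc(C(F)(F)F)c2)s1` has not yet been measured. It differs from compound 1 by 4-(trifluoromethyl)phenyl in place of 3-(trifluoromethyl)phenyl on a carbonyl carbon. Going by the values given here, no measured step touches this carbonyl-side phenyl ring; the one step that exists, from compound 1 to compound 2, is a change of the same kind on a different ring, and it stayed within the scatter. On that slender basis no step beyond the scatter is expected in this assay, so compound 3 is estimated at 9 ug/mL, within a range from 4.5 ug/mL to 18 ug/mL, which is the expected step of a 1.1-fold higher number from compound 1 to compound 3 (0.04 log units; within the scatter).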

Compound 3, half-maximal inhibitory concentration: 6.66 ug/mL
Compound 3: the middle estimate sits 1.4-fold (0.13 log units) above what was measured; the range from low to high includes it.
By their numbers in this assay, from the lowest: compounds 3, 1 and 2 (each within the scatter of the next).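

Moving the trifluoromethyl group on the ring attached to the carbonyl carbon, from 3-(trifluoromethyl)phenyl to 4-(trifluoromethyl)phenyl, gives a 1.2-fold lower number from compound 1 to compound 3 (0.09 log units; within the scatter) in this assay, so compound 1 and compound 3 cannot be told apart in this assay. Among the compounds shown here, this is the first look at that ring, and the result matches the step on the other phenyl ring, on the carbon with a double bond to nitrogen, which also stayed within the scatter: a 1.5-fold higher number from compound 1 to compound 2 (0.17 log units; within the scatter). Nothing available here speaks to what lies behind this result.

Both phenyl rings carry a trifluoromethyl group in all the compounds shown, so it remains open how a chlorine atom, a methoxy group or an amine would read at the carbonyl-side ring. Also open, going by these compounds, is how 2-(trifluoromethyl)phenyl would read on the carbonyl carbon.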